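Toward compound 4: an aromatic group on the nitrogen

This account rests on a few compounds, and the source may have more. Where it says the series, first, only, none or still open, it means among the compounds named here.

In a functional assay on DU-145 cells (Homo sapiens) for cytotoxicity, read by MTT assay, with a stated time of 72 h (on this read-out lower numbers stand for an effect already at smaller amounts and higher numbers for an effect only at larger amounts of compound), the values so far are:
- compound 1 `O=c1cc(NC2CCCCC2)cc(/C=C/c2ccccc2)o1` gives 1.23 uM
- compound 2 `O=c1cc(NC2CC2)cc(-c2ccccc2)o1` gives > 30 uM (a limit)
- compound 3 `COc1ccc(Nc2cc(C)oc(=O)c2)cc1` gives > 30 uM (a limit)

Compound 2 sits at > 30 uM and this is a limit of the assay, not a number. For the measured compounds named here, the set as a whole shows (the limit of > 30 uM in this assay, at which 2 of the 3 values shown sit), so compound 1 alone carries a true number and no step between measured compounds can be read.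

The next compound is compound 4 `Cc1ccc(Nc2cc(-c3ccccc3)oc(=O)c2)cc1`, which has 4-methylphenyl in place of cyclopropyl on a nitrogen on an aromatic ring. The expectation leans on compound 1, whose 1.23 uM shows that the shared core can reach a number in this assay. Compound 3 goes against an easy reading, since it has an aromatic ring on its nitrogen and still gives > 30 uM, again a limit. Even so, a clear move toward lower numbers, beyond the scatter, is expected, with the expected step of an at least 10-fold lower number from compound 2 to compound 4 (1.00 log units; beyond the scatter) counted from a limit and so uncertain. For compound 4 the estimated value is 3 uM, with an expected range from 0.3 uM to 30 uM.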

Compound 4, concentration for half-maximal effect: 0.073 uM
Compound 4: the middle estimate sits 41-fold (1.61 log units) above what was measured, and the stated range ends above it.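

In this assay, for the compounds shown here, this nitrogen is the first place where a single change can be read: 4-methylphenyl in place of cyclopropyl gives an at least 410-fold lower number from compound 2 to compound 4 (2.61 log units; beyond the scatter), beyond the scatter and large. Going by these compounds, the true size of the step stays unknown, since it starts from a limit: the limit of > 30 uM in this assay, at which 2 of the 4 values shown sit. Compound 3 gives > 30 uM, a limit, and it goes against any general rule that an aromatic group on the nitrogen is enough, although it differs from compound 4 in more than one place, so the effect of the change is tied to the background of compound 2 and compound 4.

Open, on these data alone, is whether the aromatic ring alone carries the step or whether the methyl of the 4-methylphenyl contributes, which a plain phenyl or a 4-chlorophenyl on the same nitrogen would separate. Also open, as far as these compounds go, is whether a benzyl group, with a carbon chain between the nitrogen and the ring, or a cyclohexyl group on the nitrogen would keep a measurable value with the rest of compound 4 unchanged.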